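This account rests on a few compounds, and the source may have more. Where it says the series, first, only, none or still open, it means among the compounds named here.

Going by the values given here, in a functional assay on A549 cells (Homo sapiens) for cytotoxicity, read by MTT assay, with a stated time of 72 h (a lower number here means a stronger inhibitor, a higher number a weaker inhibitor), compound 3 `O=C(/C=C/c1ccccc1[N+](=O)[O-])Nc1cc2c(Nc3ccc(F)c(Cl)c3)ncnc2cc1O[C@H]1CCOC1` gives 8820 nM, the higher of the two numbers so far, while compound 2 `COc1ccc(/C=C/C(=O)Nc2cc3c(Nc4ccc(F)c(Cl)c4)ncnc3cc2O[C@H]2CCOC2)c(OC)c1OC` gives 70 nM. Compound 4 `O=C(/C=C/c1ccc(F)cc1Cl)Nc1cc2c(Nc3ccc(F)c(Cl)c3)ncnc2cc1O[C@H]1CCOC1` differs from compound 3 in one place: 2-chloro-4-fluorophenyl in place of 2-nitrophenyl on a double-bonded chain carbon bound to a double-bonded chain carbon. The group changes on a double-bonded chain carbon bound to a double-bonded chain carbon.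

Among the compounds with values here, the only measured step at this place is a 130-fold higher number from compound 2 to compound 3 (2.10 log units; beyond the scatter). It is large and beyond the scatter, so a change here can clearly matter. That step involves a different incoming group, however, and says little about the direction of this one. Compound 1 `COc1cc2ncnc(Nc3ccc(F)c(Cl)c3)c2cc1NC(=O)/C=C/c1ccc(F)cc1Cl` carries the same 2-chloro-4-fluorophenyl as compound 4 but differs elsewhere. Compound 1 gives "not active" (no number reported), which argues against expecting a large gain.

In this assay, the expected result is a modest move toward a lower number, estimated as a 2.9-fold lower number from compound 3 to compound 4 (0.47 log units; beyond the scatter). The estimate for compound 4 is 3000 nM, with an expected range from 300 nM to 20000 nM.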

Compound 4, half-maximal inhibitory concentration: 5190 nM
For compound 4 the middle estimate is 1.7-fold (0.24 log units) below the measured one, and the stated range covers the measured number.
By their numbers in this assay, from the lowest: compound 2; then compounds 4 and 3 (each within the scatter of the next).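

In this assay, replacing 2-nitrophenyl with 2-chloro-4-fluorophenyl gives a 1.7-fold lower number from compound 3 to compound 4 (0.23 log units; within the scatter), so these two groups cannot be told apart here, even though one carries nitrogen and oxygen and the other fluorine and chlorine. Replacing 2,3,4-trimethoxyphenyl with the same 2-chloro-4-fluorophenyl gives a 74-fold higher number from compound 2 to compound 4 (1.87 log units; beyond the scatter), so the large change at this place now appears with two different incoming groups, and 2,3,4-trimethoxyphenyl stands apart from both. Nothing measured here gives a reason for this difference.

A phenyl carrying a single methoxy group would help show whether one methoxy group is enough to give the lower number of compound 2. An amine or a carboxylic acid on the same ring would test whether any other group can match it.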